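Amine swap on the shared core: working notes

This account rests on a few compounds, and the source may have more. Where it says the series, first, only, none or still open, it means among the compounds named here.

Measured so far:
compound 1 `CC(C(=O)NCc1ccc(C(F)(F)F)nc1NCc1ccccc1)c1ccc(NS(C)(=O)=O)c(F)c1`: 15.8 nM
compound 2 `C[C@H](C(=O)NCc1ccc(C(F)(F)F)nc1N1CC[C@H](N(C)C)C1)c1ccc(NS(C)(=O)=O)c(F)c1`: 103 nM

In a functional assay on CHO-K1 cells for antagonist activity at transient receptor potential cation channel subfamily V member 1 (Homo sapiens), read by FLIPR (a lower number here means a stronger inhibitor, a higher number a weaker inhibitor), compound 1 gives the lowest of the two numbers; compound 2 gives the higher one, and the gap between them lies beyond the scatter. Compound 3 `CC(C(=O)NCc1ccc(C(F)(F)F)nc1N1CCCCC1C)c1ccc(NS(C)(=O)=O)c(F)c1` differs from compound 1 by one change: 2-methylpiperidin-1-yl in place of benzylamino on an aromatic carbon. Among the measured compounds shown here, no measured pair shows this same change, so its size is not known. Compound 2 shows that a non-aromatic amine at this place can go with a higher number, but that is a different group. A modest rise is expected for compound 3, a 2.5-fold higher number from compound 1 to compound 3 (0.40 log units; beyond the scatter). The estimate for compound 3 in this assay is 40 nM, between 12 nM and 130 nM.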

Compound 3, inhibition constant: 2.9 nM
The estimate for compound 3 lay 14-fold (1.14 log units) above the measured number, and the stated range ends above it.
By their numbers in this assay, from the lowest: compound 3; then compound 1; then compound 2.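

In this assay, 2-methylpiperidin-1-yl in place of benzylamino on this aromatic carbon gives a 5.4-fold lower number from compound 1 to compound 3 (0.74 log units; beyond the scatter). The change removes the six-membered aromatic ring of carbon only and the hydrogen-bond donor of benzylamino, yet the number falls, so neither is required at this place on the shared core. No available evidence accounts for the size of this step.

Open, from the compounds shown here alone, is how far the methyl group matters: plain piperidin-1-yl would test that directly. Morpholin-4-yl would show whether a second ring hetero atom is accepted at this place.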